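A few compounds are considered here, and "the series" means these few. Any claim that something is new, unique, unknown or untested is made for them only; others in the source may bear on it.

Compound 1 `CC(=O)N1CCCn2nc(COc3ccccc3F)cc21` and compound 2 `CC(=O)N1CCCn2nc(COc3ccc(F)cc3)cc21` share a core carrying an acetylated ring system and a fluorophenyl attached through an oxygen on a saturated carbon; they differ only in the place of the fluorine. In a functional assay on HEK293 cells for positive allosteric modulation of metabotropic glutamate receptor 5 (Homo sapiens), read by calcium flux (on this read-out higher numbers stand for larger maximal responses and lower numbers for smaller maximal responses), compound 1 gives 60% and compound 2 gives 56%. The step of a number 4 percentage points lower from compound 1 to compound 2 (within the scatter) shows that shifting the fluorine left the response essentially unchanged. Compound 3 `CC(=O)N1CCCn2nc(COc3cccnc3)cc21` replaces the fluorophenyl with a pyridin-3-yl. In this assay compound 3 gives only a limit, < 15%, not a measured number. The steps of a number at least 45 percentage points lower from compound 1 to compound 3 (beyond the scatter) and a number at least 41 percentage points lower from compound 2 to compound 3 (beyond the scatter) are both large, and compound 3 sits at the limit of < 15% in this assay, at which 1 of the 3 values shown sits.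

Compound 4 `CC(=O)N1CCCn2nc(COc3ccncc3)cc21` is the next variation: pyridin-4-yl in place of pyridin-3-yl on an oxygen on a saturated carbon. Within the data shown here, the only steps that bear on this change are the two large drops into compound 3, which show that a pyridyl in this place goes with a small response, while the step from compound 1 to compound 2 shows that moving a substituent around the ring changed little. A step that the limit leaves unreadable from compound 3 to compound 4 is therefore expected, within the scatter. Compound 4 is estimated at 12%, with a range from 0% to 35%, and most likely this assay again reports only a limit.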

Compound 4, largest response reached (reported as percent of maximum), in percent of the reference or control that the assay uses: < 15%
Compound 4: a limit, no number (the forecaster's own chance of this, stated with the estimate: 70%); the middle value lies beyond the limit too.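

In this assay compound 4 gives < 15% as a limit of the assay and not a number. Placing pyridin-4-yl where the fluorophenyl groups stood gives a number at least 45 percentage points lower from compound 1 to compound 4 (beyond the scatter) and a number at least 41 percentage points lower from compound 2 to compound 4 (beyond the scatter) in the same assay, so among the compounds shown the large drop is not confined to pyridin-3-yl. The step between compound 3 and compound 4 cannot be read, and the two pyridyl compounds now rest at the same floor: the limit of < 15% in this assay, at which 2 of the 4 values shown sit.

From the compounds shown here alone, whether moving the ring nitrogen from the pyridin-3-yl to the pyridin-4-yl arrangement changes the response at all remains open, as does how small either response really is. Also open, going by these compounds, is how a plain phenyl, a pyridin-2-yl or a chlorophenyl on this oxygen would compare with the fluorophenyl groups of compound 1 and compound 2.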